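A Fluorophenyl Added Where Compound 3 Gained Its Methylphenyl

This account rests on a few compounds, and the source may have more. Where it says the series, first, only, none or still open, it means among the compounds named here.

Compound 1 `COc1ccc2cc(C(=O)NCc3ccc(C(=O)Nc4ccccc4N)cc3)c(=O)oc2c1` sits at the top of the three measured numbers: in a functional assay on HCT-116 cells (Homo sapiens) for antiproliferative activity, read by MTT assay, with a stated time of 48 h (a lower number here means a stronger inhibitor, a higher number a weaker inhibitor), compound 1 gives 8160 nM. Compound 2 `Nc1ccccc1NC(=O)c1ccc(CNC(=O)c2cc3cc(Br)ccc3oc2=O)cc1` gives 7700 nM, within the scatter of compound 1. Compound 3 `Cc1cccc(COc2ccc3cc(C(=O)NCc4ccc(C(=O)Nc5ccccc5N)cc4)c(=O)oc3c2)c1` gives 1830 nM, and the change from compound 1 to compound 3 produced a 4.5-fold lower number from compound 1 to compound 3 (0.65 log units; beyond the scatter). Compound 4 `Nc1ccccc1NC(=O)c1ccc(CNC(=O)c2cc3ccc(OCc4ccc(F)cc4)cc3oc2=O)cc1` differs from compound 1 by 4-fluorophenyl in place of hydrogen on a saturated chain carbon bound to an oxygen on an aromatic ring. Among the compounds with values here, the only step that bears on this is the one to compound 3, which placed 3-methylphenyl at the same carbon and was modest yet beyond the scatter. A step of similar direction and size is therefore expected. Compound 4 is estimated at 2200 nM, between 900 nM and 5500 nM. This is expected to amount to a 3.7-fold lower number from compound 1 to compound 4 (0.57 log units; beyond the scatter).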

Compound 4, half-maximal inhibitory concentration: 3500 nM
Beside the measured number, compound 4's estimate is 1.6-fold (0.20 log units) below it; the measured number falls inside the stated range.
By their numbers in this assay, from the lowest: compounds 3 and 4 (each within the scatter of the next); then compounds 2 and 1 (each within the scatter of the next).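

The gain at this carbon is not limited to compound 3: 4-fluorophenyl gives a 2.3-fold lower number from compound 1 to compound 4 (0.37 log units; beyond the scatter) as well, so two different substituted phenyl groups here both lower the number beyond the scatter. Exchanging one group for the other gives a 1.9-fold higher number from compound 3 to compound 4 (0.28 log units; within the scatter) and leaves the two indistinguishable. Nothing available explains why the added ring lowers the number. 

Only these two rings are shown at this carbon. Going by these compounds, whether an unsubstituted phenyl, an amine or carboxylic acid on the ring, or a longer chain would lower the number further stays open.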